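The source may report more compounds than this note shows. Statements on the series, on what has been measured and on what is new or still open speak of the compounds shown alone.

Of the compounds shown here, three sharing one core have been measured in a functional assay on HeLa cells for antagonist activity at G-prodeshotein coupled receptor 4 (Homo sapiens), read by HTRF and cAMP accumulation, with a stated time of 15 min; a lower number here means a stronger inhibitor, a higher number a weaker inhibitor. Compound 1, `CCc1nn2c(C)cc(C)nc2c1Cc1ccc(CCC(O)C2CCNCC2)cc1`, gives 24 nM. Compound 2, `CCc1nn2c(C)cc(C)nc2c1Cc1ccc(CCC(=O)N2CCNCC2)cc1`, gives 53 nM. Compound 3, `CCc1nn2c(C)cc(C)nc2c1Cc1ccc(/C=C/CN2CCN(C[C@@H](O)CO)CC2)cc1`, gives 21 nM. Among these three numbers compound 2 stands highest, so it is the weakest inhibitor shown: the step from compound 1 to compound 2 reads a 2.2-fold higher number from compound 1 to compound 2 (0.34 log units; beyond the scatter), and compound 3 lies lower still.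

Compound 4, `CCc1nn2c(C)cc(C)nc2c1Cc1ccc(CCCC2(O)CCNCC2)cc1`, has not yet been measured. Its difference from compound 2 is (4-hydroxypiperidin-4-yl)methyl in place of (piperazin-1-yl)carbonyl on a saturated chain carbon, two bonds along the chain from an aromatic carbon. For the measured compounds named here, the one measured step that bears on this is the move from compound 1 to compound 2, which lifted the number by a 2.2-fold higher number from compound 1 to compound 2 (0.34 log units; beyond the scatter). Compound 4 brings back a secondary amine in a six-membered ring together with a hydroxy group, features that compound 1 also carries, while the carbonyl of compound 2 is gone. The step from compound 2 to compound 4 is therefore expected to run the other way, about a 2.1-fold lower number from compound 2 to compound 4 (0.33 log units; beyond the scatter). Compound 4 is estimated at 25 nM, with a likely range from 10 nM to 70 nM.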

Compound 4, half-maximal inhibitory concentration: 50 nM
The estimate for compound 4 lay 2.0-fold (0.30 log units) below the measured number; low and high end bracket the measured number.
By their numbers in this assay, from the lowest: compounds 3 and 1 (each within the scatter of the next); then compounds 4 and 2 (each within the scatter of the next).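

In this assay, the swap of (piperazin-1-yl)carbonyl for (4-hydroxypiperidin-4-yl)methyl gives a 1.1-fold lower number from compound 2 to compound 4 (0.03 log units; within the scatter), so at this position the two groups cannot be told apart, even though only the first holds a carbonyl. Compound 1 and compound 4 both carry a hydroxy group and a piperidine ring, yet moving the hydroxy group from the chain carbon onto the ring gives a 2.1-fold higher number from compound 1 to compound 4 (0.32 log units; beyond the scatter), which shows that having these two features is not enough to match compound 1. No information is available here on why the numbers fall this way.

As far as these compounds go, it remains open whether a plain piperidin-4-ylmethyl group, with no hydroxy group, would read closer to compound 1 or to compound 4. Also open, from the compounds shown here alone, is how a methoxy group in place of the hydroxy, or a longer chain, would read.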